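Removing an Acetyl Group from Compound 3

The compounds below may be only part of what the source reports. "The series", "measured", "known", "first", "only" and "open" are said of these compounds alone.

Compound 3 `C=C1CC[C@H]2[C@@](C)(CC[C@@H](OC(C)=O)[C@@]2(C)C(=O)OC)[C@@H]1C/C=C1\C=COC1=O` gives 69700 nM in a functional assay on NIH3T3 cells (Mus musculus) for inhibition, read by MTT assay, with a stated time of 72 h; a lower number here means a stronger inhibitor, a higher number a weaker inhibitor. Two relatives sharing its core have also been tested: compound 1 `C=C1CC[C@H]2[C@@](C)(CC[C@@H](O)[C@@]2(C)C(=O)OC)[C@@H]1CCC1=CCOC1=O` and compound 2 `C=C1CC[C@H]2[C@@](C)(CC[C@@H](O)[C@@]2(C)C(=O)OC)[C@@H]1/C=C/C1=CCOC1=O`. Compound 3 lies within the usual scatter of both, so it cannot be ranked against either.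

Compound 4 `C=C1CC[C@H]2[C@@](C)(CC[C@@H](O)[C@@]2(C)C(=O)OC)[C@@H]1C/C=C1\C=COC1=O` differs from compound 3 by a single change: hydrogen in place of acetyl on an oxygen on a saturated carbon, which means acetoxy to hydroxy. Among the compounds with values here, no measured step isolates this change. The only one available, a 1.8-fold higher number from compound 1 to compound 2 (0.26 log units; within the scatter), lies elsewhere in the molecule and stays within the scatter. Still, compound 1 at 60600 nM and compound 2 at 111000 nM both carry the hydroxy, and each differs from compound 4 only elsewhere. Their numbers sit close to that of compound 3, so no shift beyond the scatter is expected in this assay, and no direction can be favoured. The expected change is small: a 1.1-fold higher number from compound 3 to compound 4 (0.03 log units; within the scatter). Compound 4 is therefore estimated at 75000 nM, with an expected range from 35000 nM to 150000 nM.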

Compound 4, half-maximal inhibitory concentration: 177000 nM
Estimate against measurement, compound 4: 2.4-fold (0.37 log units) below; the measured number lies above the stated range.
By their numbers in this assay, from the lowest: compounds 1, 3, 2 and 4 (each within the scatter of the next, the first and the last beyond it).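

In this assay, acetoxy to hydroxy on this saturated carbon now has a measured step of its own, and a 2.5-fold higher number from compound 3 to compound 4 (0.40 log units; beyond the scatter) shows that the hydroxy compound is the modestly weaker inhibitor of this pair. Changes elsewhere in the molecule, with the hydroxy kept, give two different readings: a 2.9-fold higher number from compound 1 to compound 4 (0.47 log units; beyond the scatter) separates that pair, whereas a 1.6-fold higher number from compound 2 to compound 4 (0.20 log units; within the scatter) does not. The number therefore depends on more than this oxygen, and nothing available explains either step.

The compounds shown leave open whether the acetyl itself matters or whether another group on this oxygen, such as a methyl ether or a benzoate ester, would give a similar number. The acetoxy forms of compound 1 and compound 2 would show whether this step carries over to those molecules.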